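The source may hold more compounds than are shown below. What is called first, only, known or untested is meant among the compounds shown, and "the series" means these compounds.

In an assay on isolated protein with Bile acid receptor (Homo sapiens) as the target (on this read-out higher numbers stand for an effect only at larger amounts of compound and lower numbers for an effect already at smaller amounts), three compounds built on one shared core have been measured. Compound 1 `COC(=O)/C=C/c1cccc(N(Cc2ccc(-c3c(OC)cccc3OC)cc2)C(=O)C2CCCCC2)c1` carries a 2,6-dimethoxyphenyl group and gives 77 nM. Compound 2 `COC(=O)/C=C/c1cccc(N(Cc2ccc(Br)cc2)C(=O)C2CCCCC2)c1` carries bromo at that place and gives only a limit of the assay, > 1000 nM. Compound 3 `COC(=O)/C=C/c1cccc(N(Cc2ccc(/C=C/C(=O)OCc3ccccc3)cc2)C(=O)C2CCCCC2)c1` carries 2-(benzyloxycarbonyl)ethenyl there and likewise gives only a limit, > 1000 nM. Compound 3 thus sits at the limit rather than at a readable number, as does compound 2 (the limit of > 1000 nM in this assay, at which 2 of the 3 values shown sit). The step of an at least 12-fold higher number from compound 1 to compound 3 (1.11 log units; beyond the scatter) is large, and the step of an at least 12-fold higher number from compound 1 to compound 2 (1.11 log units; beyond the scatter) is equally large. The step that the two limits leave unreadable from compound 2 to compound 3 cannot be read, since both ends are limits.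

Compound 4 `COC(=O)/C=C/c1cccc(N(Cc2ccc(-c3cccc(OC(F)(F)F)c3)cc2)C(=O)C2CCCCC2)c1` has not yet been measured. It differs from compound 3 in one place: 3-(trifluoromethoxy)phenyl in place of 2-(benzyloxycarbonyl)ethenyl on an aromatic carbon. The entering 3-(trifluoromethoxy)phenyl is an aromatic ring on an aromatic carbon, as is the 2,6-dimethoxyphenyl of compound 1, whereas the leaving group of compound 3 is an open chain carrying two double bonds outside aromatic rings. Because the step of an at least 12-fold higher number from compound 1 to compound 3 (1.11 log units; beyond the scatter) was large and went toward the limit, the reverse kind of change is expected to bring the number back down, by an estimated at least 6.6-fold lower number from compound 3 to compound 4 (0.82 log units; beyond the scatter). Compound 4 is therefore expected at about 150 nM, with a range from 40 nM to 900 nM.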

Compound 4, half-maximal effective concentration: 420 nM
Beside the measured number, compound 4's estimate is 2.8-fold (0.45 log units) below it, within the range that was stated.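

At this position, para to a large group, the result shows that a directly attached aromatic ring gives a readable number in this assay with a substituent other than the two methoxy groups of compound 1, and the change shows as an at least 2.3-fold lower number from compound 3 to compound 4 (0.37 log units; beyond the scatter) and as an at least 2.3-fold lower number from compound 2 to compound 4 (0.37 log units; beyond the scatter). The ring alone does not settle the outcome, however: exchanging 2,6-dimethoxyphenyl for 3-(trifluoromethoxy)phenyl gives a 5.5-fold higher number from compound 1 to compound 4 (0.74 log units; beyond the scatter), so among these compounds the substituents on the ring, or where they sit on it, also matter. The first two steps give only minimum sizes, because one end of each is not a number: the limit of > 1000 nM in this assay, at which 2 of the 4 values shown sit.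

The compounds shown leave open whether the difference between compound 1 and compound 4 follows the kind of substituent or its place on the ring, since the two compounds differ in both. They also do not show how a plain phenyl ring would compare, or a phenyl ring carrying an amine or a carboxylic acid.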